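The compounds below may be only part of what the source reports. "The series", "measured", "known", "first", "only" and "open" are said of these compounds alone.

In a functional assay on the whole organism for inhibition, with Rattus norvegicus as the target, read by cytopathic effect and paw edema, at a dose of 100 mg/kg by the oral route (on this read-out lower numbers stand for less inhibition and higher numbers for more inhibition at the one dose given (going by the name of the read-out)), compound 2 `CN(C)CCNC(=O)c1c(O)c2cccnc2n(-c2ccccc2)c1=O` gives 18.4%, the second highest of the three numbers, close to compound 1 `CNC(=O)c1c(O)c2cccnc2n(-c2ccccc2)c1=O`, which gives 21%, and well apart from compound 3 `Cc1ccc(NC(=O)c2c(O)c3cccnc3n(-c3ccccc3)c2=O)cc1`, which gives 2.2%. Compound 4 `Cc1ccccc1NC(=O)c1c(O)c2cccnc2n(-c2ccccc2)c1=O` differs from compound 2 by 2-methylphenyl in place of 2-(dimethylamino)ethyl on an amide-type nitrogen. Among the compounds with values here, two measured steps bear on this change, both placing 4-methylphenyl on an amide-type nitrogen: a number 16.2 percentage points lower from compound 2 to compound 3 (beyond the scatter) and a number 18.8 percentage points lower from compound 1 to compound 3 (beyond the scatter). A fall of the same order beyond the scatter is therefore expected for the move to 2-methylphenyl, giving an estimated step of a number 14.4 percentage points lower from compound 2 to compound 4 (beyond the scatter). Compound 4 is accordingly expected to give 4%, within a range from 0% to 13%.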

Compound 4, a percentage reported as inhibition, in the whole organism at one dose (the size of the read-out at that dose, not a potency): 9.8%
Compound 4: middle estimate off by 5.8 percentage points, on the low side, within the range that was stated.
By their numbers in this assay, from the lowest: compounds 3, 4, 2 and 1 (each within the scatter of the next, the first and the last beyond it).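

In this assay, 2-methylphenyl on the amide-type nitrogen cannot be told apart from 2-(dimethylamino)ethyl (a number 8.6 percentage points lower from compound 2 to compound 4 (within the scatter)) or from 4-methylphenyl (a number 7.6 percentage points higher from compound 3 to compound 4 (within the scatter)), yet it stays clearly apart from methyl (a number 11.2 percentage points lower from compound 1 to compound 4 (beyond the scatter)). Within the data shown here, compound 4 thus bridges the gap between compound 2 and compound 3, which the earlier compounds showed as beyond the scatter. Nothing measured here explains these numbers.

Going by these compounds, whether an unsubstituted phenyl, a benzyl or a longer chain ending in an amine on this nitrogen would sit nearer compound 1 or compound 3 remains open.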